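A few compounds are considered here, and "the series" means these few. Any claim that something is new, unique, unknown or untested is made for them only; others in the source may bear on it.

Of the compounds shown here, two built on the same core have been measured. Compound 1 `Nc1scc(CN2CCN(c3cccc(C(F)(F)F)c3)CC2)c1C(=O)c1ccc(Cl)cc1` and compound 2 `Nc1scc(CN2CCN(c3c(F)cccc3F)CC2)c1C(=O)c1cccc(C(F)(F)F)c1` were both tested in an assay on CHO cells for displacement of a labelled ligand from adenosine receptor A1 (Homo sapiens), read by scintillation counting, with a stated time of 120 min, tested at 10 uM; a higher number here means more inhibition at the concentration tested (going by the name of the read-out), a lower number less inhibition. In this assay compound 1 gives 0%, and in this assay compound 2 gives 0%. The two values sit level with each other at the digits reported, so the inhibition in this assay is neither higher nor lower for one compound than for the other. Compound 2 differs from compound 1 in more than one place, so no single step can be read between them.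

Compound 3 `Nc1scc(CN2CCN(c3cccc4ccccc34)CC2)c1C(=O)c1ccc(Cl)cc1` has not yet been measured. It differs from compound 1 in one place: naphthalen-1-yl in place of 3-(trifluoromethyl)phenyl on an amine nitrogen in a ring. Since compound 1 gives 0% in this assay and no change between measured compounds has been observed, nothing here points to a shift. The step is expected to be no change at the digits printed from compound 1 to compound 3 (within the scatter), none beyond the scatter. Compound 3 is therefore expected to give 0% in this assay, with a range from -10% to 15%.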

Compound 3, a percentage reported as inhibition, at one concentration (the size of the read-out at that concentration, not a potency): 1%
Beside the measured number, compound 3's estimate is 1 percentage points below it, within the range that was stated.
By their numbers in this assay, from the lowest: compounds 1, 2 and 3 (each within the scatter of the next).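

In this assay, among the compounds shown here, placing naphthalen-1-yl in place of 3-(trifluoromethyl)phenyl on an amine nitrogen in a ring gives a number 1 percentage points higher from compound 1 to compound 3 (within the scatter) and is the first step in this set that can be read at a single place. The two groups have the same count of heavy atoms, yet the entering group carries two six-membered aromatic rings of carbon only and no fluorine, so a second aromatic ring can replace the trifluoromethyl group here without the reading moving beyond the scatter. Nothing measured here offers an explanation for this result, and with all the readings so close to nothing, the step gives no sign that this position can bring out inhibition.

A single exchange between two aromatic groups says little about the position as a whole, so a benzyl group, a pyridine ring or a short chain ending in an amine or a carboxylic acid on the same nitrogen could still behave differently. Going by these compounds, it also remains open whether the shared core can give a clear reading in this assay with any group at this position.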